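Anilide series: allyloxy replacing pyridinyloxy, cytotoxicity check

The source may hold more compounds than are shown below. What is called first, only, known or untested is meant among the compounds shown, and "the series" means these compounds.

Measured so far in an ADME assay on PC-3 cells (Homo sapiens) for cytotoxicity, read by WST assay, tested at 100 uM; on this read-out lower numbers stand for less inhibition and higher numbers for more inhibition at the one concentration tested (going by the name of the read-out):
Compound 1 `O=C(Nc1cccc(Oc2ccccn2)c1)C1CCCN(C(=O)c2cc(C(F)(F)F)cc(C(F)(F)F)c2)C1` gives 0%.
Compound 2 `O=C(Nc1ccc(Cl)cc1)C1CCCN(C(=O)c2cccc(-c3nccs3)c2)C1` gives 32%.
Compound 3 `COCc1cccc(C(=O)N2CCCC(C(=O)Nc3ccc(Cl)cc3)C2)c1` gives 0%.

Compound 1 stands level with compound 3 at the digits printed, together the lowest of the three numbers; compound 2 stands higher, beyond the scatter. Compound 4 `C=CCOc1cccc(NC(=O)C2CCCN(C(=O)c3cc(C(F)(F)F)cc(C(F)(F)F)c3)C2)c1` differs from compound 1 by allyl in place of pyridin-2-yl on an oxygen on an aromatic ring. Within the data shown here, the only measured step, a number 32 percentage points lower from compound 2 to compound 3 (beyond the scatter), sits at a different place, on an aromatic carbon, and so does not bear on this change. With nothing measured at the aryl-ether position, the expectation rests on compound 1 alone, which gave 0% in this assay. Compound 4 is therefore expected to show no step beyond the scatter, a number 3 percentage points higher from compound 1 to compound 4 (within the scatter). Compound 4 is estimated at 3%, within 0% to 20%.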

Compound 4, a percentage reported as inhibition, at one concentration (the size of the read-out at that concentration, not a potency): 0%
For compound 4 the middle estimate is 3 percentage points above the measured one; measured number inside the range.
By their numbers in this assay, from the lowest: compounds 1, 3 and 4 (each within the scatter of the next); then compound 2.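

In this assay, the position on the oxygen now has a step of its own: allyl in place of pyridin-2-yl gives no change at the digits printed from compound 1 to compound 4 (within the scatter). On the core of compound 1, the low number therefore does not depend on the pyridin-2-yl ring, and this change does not raise the read-out. No evidence on hand accounts for this result.

Still open, going by these compounds, is whether a longer chain, an amine or a carboxylic acid on this oxygen would move the read-out. Also open, on these data alone, is whether the same change would behave alike on the core of compound 2.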